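Vinyl to Phenyl Exchange and Its Expected Effect on Cytotoxicity

This account rests on a few compounds, and the source may have more. Where it says the series, first, only, none or still open, it means among the compounds named here.

The study covers four compounds examined in an ADME assay on J774.1 cells (Mus musculus) for cytotoxicity, with a stated time of 48 h; a lower number here means that less compound is needed, a higher number that more compound is needed for the effect. Compound 2 `C=CCN1[C@@H](c2ccccn2)CC(O)=C(C(=O)OC)[C@H]1c1ccccn1` gives 35 uM in this assay. Compound 3 `COC(=O)C1=C(O)C[C@H](c2ccccn2)N(Cc2ccccc2)[C@@H]1c1ccccn1`, which carries phenyl in place of vinyl on a saturated chain carbon bound to an amine nitrogen in a ring, gives 33.2 uM in this assay. The step of a 1.1-fold lower number from compound 2 to compound 3 (0.02 log units; within the scatter) is therefore within the usual scatter, and the two values are treated as equivalent.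

Compound 1 `C=CCN1[C@H](c2ccc([N+](=O)[O-])cc2)C(C(=O)OCC)C(=O)C(C(=O)OCC)[C@@H]1c1ccc([N+](=O)[O-])cc1` reaches only a limit in this assay, namely > 100 uM, as recorded in the limit of > 100 uM in this assay, at which 1 of the 3 values shown sits. The difference between the core of compound 1 and the core of compound 2 is not broken down here.

Compound 4 `CCOC(=O)C1C(=O)C(C(=O)OCC)[C@H](c2ccc([N+](=O)[O-])cc2)N(Cc2ccccc2)[C@@H]1c1ccc([N+](=O)[O-])cc1` has not yet been measured in this assay. It differs from compound 1 by the same change (phenyl in place of vinyl on a saturated chain carbon bound to an amine nitrogen in a ring), at the same place as in the pair of compound 2 and compound 3. Since that change left the value essentially unmoved in a 1.1-fold lower number from compound 2 to compound 3 (0.02 log units; within the scatter), and since compound 1 sits at the limit described in the limit of > 100 uM in this assay, at which 1 of the 3 values shown sits, compound 4 is expected to remain near that limit, with an estimated value of 150 uM in this assay. The expected step that the limit leaves unreadable from compound 1 to compound 4 rests on the near-flat step a 1.1-fold lower number from compound 2 to compound 3 (0.02 log units; within the scatter) alone, so compound 4 is estimated to lie somewhere between 60 uM and 400 uM.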

Compound 4, concentration for half-maximal effect: > 100 uM
Compound 4 ended at the assay's limit; the forecaster's own chance of this, stated with the estimate: 70%; the middle value does not contradict the limit.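

In this assay compound 1 and compound 4 both stand at a limit of the assay and not at a number, so no step can be read between them: the limit of > 100 uM in this assay, at which 2 of the 4 values shown sit.

The compounds shown leave open how far the true values of compound 1 and compound 4 lie from that limit, and whether phenyl in place of vinyl changes anything on the core of compound 1.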